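The source may hold more compounds than are shown below. What is called first, only, known or untested is meant among the compounds shown, and "the series" means these compounds.

Measured compounds:
- compound 1, `Cc1ccc(OCC(=O)N(CCO)Cc2cccs2)cc1`: 900 nM
- compound 2, `CCN(Cc1nccs1)C(=O)COc1ccc(C)cc1`: 3060 nM

Both were tested in an assay on HEK293 cells for agonist activity at transient receptor potential cation channel subfamily M member 8 (Homo sapiens), read by fluorescence and calcium flux, with a stated time of 15 min; a higher number here means that more compound is needed for the effect, a lower number that less compound is needed. Of the two numbers, compound 1 has the lower one; compound 2 sits at a higher number, and the gap between them is beyond the usual scatter, so compound 1 needs less compound for the effect than compound 2 does. Going by the values given here, no single-point step between measured compounds is available, so nothing is known yet about how a change at the amide-type nitrogen alone shifts the result.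

Compound 3, `Cc1ccc(OCC(=O)N(Cc2cccs2)c2ccccn2)cc1`, has not been measured. It differs from compound 1 in one place: pyridin-2-yl in place of 2-hydroxyethyl on an amide-type nitrogen. The 2-hydroxyethyl group leaves and a pyridin-2-yl group takes its place on the amide-type nitrogen, while the rest of the molecule, including the thiophene-bearing carbon chain and the shared core, stays as in compound 1.

Among the compounds with values here, with no comparable step in hand, the expectation for compound 3 in this assay is a small shift, if any, with the estimated step of a 1.3-fold higher number from compound 1 to compound 3 (0.12 log units; within the scatter) from compound 1 and a wide range of uncertainty. Compound 3 is expected to give about 1200 nM, somewhere between 300 nM and 5000 nM.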

Compound 3, half-maximal effective concentration: 200 nM
Estimate against measurement, compound 3: 6.0-fold (0.78 log units) above; measured number outside the range, below it.
By their numbers in this assay, from the lowest: compound 3; then compound 1; then compound 2.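

In this assay, the amide-type nitrogen proves to be a place where a single change clearly moves the result: pyridin-2-yl in place of 2-hydroxyethyl gives a 4.5-fold lower number from compound 1 to compound 3 (0.65 log units; beyond the scatter) and so less compound is needed for the effect. This change takes away the hydrogen-bond donor of the 2-hydroxyethyl group and brings in a six-membered aromatic ring with more heavy atoms, which shows that this donor is not required for activity in this pair and that the ring is tolerated on this nitrogen. No measurement here gives a reason for the step.

The step swaps several features at once, so it leaves open whether the gain comes with the ring itself, with its nitrogen atom, or with the loss of the hydroxyl group. A plain phenyl group on the same nitrogen would test the ring without its nitrogen atom, while a 2-methoxyethyl group would keep the chain of compound 1 without its hydrogen-bond donor, so each could help to separate these possibilities.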